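A few compounds are considered here, and "the series" means these few. Any claim that something is new, unique, unknown or untested is made for them only; others in the source may bear on it.

Values in a functional assay on Bel-7402 cells (Homo sapiens) for cytotoxicity, read by MTT assay, with a stated time of 72 h; on this read-out higher numbers stand for weaker inhibition and lower numbers for stronger inhibition
- compound 1 `C=C1C(=O)[C@@]23C(=O)OC[C@]4(C(=O)CCC(C)(C)[C@H]4C=O)[C@@H]2CC[C@@H]1[C@H]3O` gives 5030 nM
- compound 2 `C=C1C(=O)[C@@]23C(=O)OC[C@]4(C(=O)CCC(C)(C)[C@H]4C=O)[C@@H]2CC[C@@H]1[C@H]3OC(C)=O` gives 1730 nM
- compound 3 `C=C1C(=O)[C@@]23C(=O)OC[C@]4(C(=O)CCC(C)(C)[C@H]4C=O)[C@@H]2CC[C@@H]1[C@H]3OC(=O)c1ccc(C(F)(F)F)cc1` gives 3990 nM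

Compound 3 sits at the upper end of these numbers, not separable from one neighbour and clear of the other. The two gaps read (a 1.3-fold lower number from compound 1 to compound 3 (0.10 log units; within the scatter)) and (a 2.3-fold higher number from compound 2 to compound 3 (0.36 log units; beyond the scatter)).

The next structure is compound 4 `C=C1C(=O)[C@@]23C(=O)OC[C@]4(C(=O)CCC(C)(C)[C@H]4C=O)[C@@H]2CC[C@@H]1[C@H]3OC(=O)c1ccccc1F`, with 2-fluorophenyl in place of 4-(trifluoromethyl)phenyl on a carbonyl carbon. Within the data shown here, no measured step exchanges one substituted phenyl for another. The closest evidence is the modest change at the same carbonyl carbon (a 2.3-fold higher number from compound 2 to compound 3 (0.36 log units; beyond the scatter)). The other steps are also small (a 2.9-fold lower number from compound 1 to compound 2 (0.46 log units; beyond the scatter)) and (a 1.3-fold lower number from compound 1 to compound 3 (0.10 log units; within the scatter)). Changes at this oxygen have therefore moved the number only modestly, and no step beyond the scatter is expected in this assay. The expected step is small (a 1.2-fold lower number from compound 3 to compound 4 (0.08 log units; within the scatter)). Compound 4 is estimated at 3300 nM in this assay with an expected range from 1500 nM to 7000 nM.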

Compound 4, half-maximal inhibitory concentration: 3950 nM
Compound 4: the middle estimate sits 1.2-fold (0.08 log units) below what was measured, within the range that was stated.
By their numbers in this assay, from the lowest: compound 2; then compounds 4, 3 and 1 (each within the scatter of the next).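

In this assay, among these compounds, the first exchange of one substituted phenyl for another, 2-fluorophenyl in place of 4-(trifluoromethyl)phenyl on the carbonyl carbon, leaves the two compounds inseparable (a 1.0-fold lower number from compound 3 to compound 4 (0.00 log units; within the scatter)), and compound 4 also cannot be separated from the compound with hydrogen on this oxygen (a 1.3-fold lower number from compound 1 to compound 4 (0.10 log units; within the scatter)). The gap to the acetyl compound recurs with this second phenyl group (a 2.3-fold higher number from compound 2 to compound 4 (0.36 log units; beyond the scatter)), so among the compounds shown, compound 2 alone stands apart, and only modestly. No measurement at hand accounts for the two phenyl groups reading alike.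

Going by these compounds, whether an aminoalkyl or carboxylic acid group on this oxygen, or a longer alkyl chain in place of the methyl of the acetyl, would stay within this narrow band remains open. Also open, on these data alone, is how far the number moves with changes elsewhere on the shared core.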